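Swapping the aryl ring of a hydrazone urea series

A few compounds are considered here, and "the series" means these few. Any claim that something is new, unique, unknown or untested is made for them only; others in the source may bear on it.

Of the compounds shown here, two have been measured in a functional assay on HT-29 cells (Homo sapiens) for cytotoxicity, read by MTT assay, with a stated time of 72 h; a higher number here means a weaker inhibitor, a lower number a stronger inhibitor. Compound 1 `COc1ccc(/C=N/NC(=O)Nc2ccc(Oc3ccnc(-c4nncn4CCN(C)C)c3)c(F)c2)c(OC)c1` gives 1780 nM, while compound 2 `CN(C)CCn1cnnc1-c1cc(Oc2ccc(NC(=O)N/N=C/c3ccc(O)c(Br)c3)cc2F)ccn1` gives 450 nM. Going by the values given here, the one measured step, a 4.0-fold lower number from compound 1 to compound 2 (0.60 log units; beyond the scatter), shows that exchanging the aromatic ring on a carbon with a double bond to nitrogen can shift this assay by a clear margin. Compound 2 thus stands at the lower of the two numbers seen so far.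

Compound 3 `CN(C)CCn1cnnc1-c1cc(Oc2ccc(NC(=O)N/N=C/c3c(O)ccc4ccccc34)cc2F)ccn1` alters compound 2 at that same place: 2-hydroxynaphthalen-1-yl in place of 3-bromo-4-hydroxyphenyl on a carbon with a double bond to nitrogen. Among the compounds with values here, no measured step covers this exact exchange; the only step that bears on the position is a 4.0-fold lower number from compound 1 to compound 2 (0.60 log units; beyond the scatter), which was modest. A change of similar or smaller size is therefore expected, with no firm direction. Compound 3 is estimated at 650 nM, within 150 nM to 2800 nM. This estimate means a 1.4-fold higher number from compound 2 to compound 3 (0.16 log units; within the scatter).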

Compound 3, half-maximal inhibitory concentration: 670 nM
The estimate for compound 3 lay 1.0-fold (0.01 log units) below the measured number, and the stated range covers the measured number.
By their numbers in this assay, from the lowest: compounds 2 and 3 (each within the scatter of the next); then compound 1.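

In this assay, this position takes a larger group without a change that can be told from the scatter: 2-hydroxynaphthalen-1-yl, with two aromatic rings and no bromine, in place of 3-bromo-4-hydroxyphenyl gives a 1.5-fold higher number from compound 2 to compound 3 (0.17 log units; within the scatter) and so leaves compound 2 and compound 3 level. Against the 2,4-dimethoxyphenyl group, the same exchange gives a 2.7-fold lower number from compound 1 to compound 3 (0.42 log units; beyond the scatter) as its result, so both groups carrying a hydroxyl have lower numbers than that group, and the bromine is not needed for this. No measurement is available that explains these numbers.

The compounds shown leave open whether the hydroxyl itself counts, which a plain phenyl ring or a 2-methoxynaphthalen-1-yl group would test. Going by these compounds, how a ring carrying an amine or a carboxylic acid behaves at this place also remains open.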